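The source may report more compounds than this note shows. Statements on the series, on what has been measured and on what is new or still open speak of the compounds shown alone.

Values measured in a physicochemical assay for solubility, using the shake flask method, measured as kinetic solubility, with a stated time of 20 h, at pH 2; on this read-out higher numbers stand for higher solubility and lower numbers for lower solubility:
- Compound 1 `COc1ccnc(Nc2cc3[nH]c(-c4cccc(C(F)(F)F)c4)nc3cn2)c1`: < 5000 nM (a limit)
- Compound 2 `Fc1ccc(-c2nc3cnc(Nc4ccccn4)cc3[nH]2)cc1C(F)(F)F`: 7000 nM
- Compound 3 `Fc1ccc(-c2nc3cnc(Nc4ccccn4)cc3[nH]2)cc1F`: 125000 nM

Compound 1 has no exact number on this read-out. Its entry, < 5000 nM, is a limit of the assay.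

Compound 4 `Fc1cnc(Nc2cc3[nH]c(-c4cccc(C(F)(F)F)c4)nc3cn2)c(F)c1` has not yet been measured. It differs from compound 1 by one change, with 3,5-difluoropyridin-2-yl in place of 4-methoxypyridin-2-yl on a nitrogen on an aromatic ring.

Among the compounds with values here, no measured step covers this exchange. The only one available, an 18-fold higher number from compound 2 to compound 3 (1.25 log units; beyond the scatter), is large and beyond the scatter, but it is a different change, fluoro in place of trifluoromethyl on an aromatic carbon. It bears on compound 4 only indirectly, since compound 1 and compound 4 both keep the trifluoromethyl group that this step removes. Compound 2 also carries that group and gives 7000 nM, so a value near that of compound 2 is expected rather than one near compound 3.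

The estimated step is a step that the limit leaves unreadable from compound 1 to compound 4, and no change beyond the scatter is expected, although the starting point is only a limit. For compound 4 the expected value in this assay is 4000 nM, with an estimated range from 1000 nM to 12000 nM.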

Compound 4, solubility: < 5000 nM
Compound 4 gave a limit, no number; the forecaster's own chance of this, stated with the estimate: 50%; the middle value lies beyond the limit too.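

In this assay compound 4 gives < 5000 nM, which is a limit and not a number. Compound 1 also gives a limit, so no step can be read between compound 1 and compound 4: the limit of < 5000 nM in this assay, at which 2 of the 4 values shown sit.

The compounds shown leave open how 3,5-difluoropyridin-2-yl and 4-methoxypyridin-2-yl compare in this assay.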